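Restoring the Amine Hydrogen on a Sulfonamide Chain

The compounds below may be only part of what the source reports. "The series", "measured", "known", "first", "only" and "open" are said of these compounds alone.

Compound 1 `O=S(=O)(NCCCNCc1cccc2ccccc12)c1cc(C(F)(F)F)cc(C(F)(F)F)c1`: 2700 nM
Compound 2 `O=S(=O)(NCCCNCc1ccc(Cl)cc1)c1cc(C(F)(F)F)cc(C(F)(F)F)c1`: 4900 nM
Compound 3 `CN(CCCNS(=O)(=O)c1cc(C(F)(F)F)cc(C(F)(F)F)c1)Cc1ccccc1`: > 50000 nM

The three compounds share one core and differ only in the group carried on a saturated chain carbon, three bonds along the chain from a sulfonamide nitrogen. In a functional assay on PANC-1 cells (Homo sapiens) for inhibition, read by MTT assay, with a stated time of 72 h (on this read-out higher numbers stand for weaker inhibition of growth and lower numbers for stronger inhibition of growth), compound 1 gives 2700 nM. Compound 2 gives 4900 nM, and the step of a 1.8-fold higher number from compound 1 to compound 2 (0.26 log units; within the scatter) shows that exchanging one aromatic group for another changed little. For compound 3 the assay reports only a limit, > 50000 nM, as recorded in the limit of > 50000 nM in this assay, at which 1 of the 3 values shown sits. Within the data shown here, compound 3 therefore stands apart as the one compound without an exact number, and the step of an at least 10-fold higher number from compound 2 to compound 3 (1.00 log units; beyond the scatter) is the only measured change that moved the read-out beyond the scatter.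

Compound 4, `COc1ccc(CNCCCNS(=O)(=O)c2cc(C(F)(F)F)cc(C(F)(F)F)c2)cc1`, has not yet been measured. It differs from compound 3 by (4-methoxybenzyl)amino in place of benzyl(methyl)amino on a saturated chain carbon, three bonds along the chain from a sulfonamide nitrogen. This change removes the methyl that entered in the step of an at least 10-fold higher number from compound 2 to compound 3 (1.00 log units; beyond the scatter), while the exchange of aromatic group resembles the step of a 1.8-fold higher number from compound 1 to compound 2 (0.26 log units; within the scatter), which stayed within the scatter. A step of an at least 10-fold lower number from compound 3 to compound 4 (1.00 log units; beyond the scatter) is therefore expected, toward stronger inhibition of growth. Compound 4 is estimated to give 5000 nM, with a range from 2000 nM to 20000 nM.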

Compound 4, concentration for 50% growth inhibition: 11000 nM
The estimate for compound 4 lay 2.2-fold (0.34 log units) below the measured number; measured number inside the range.
By their numbers in this assay, from the lowest: compounds 1 and 2 (each within the scatter of the next); then compound 4. At a limit, above all of these: compound 3.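

In this assay, the step of an at least 4.5-fold lower number from compound 3 to compound 4 (0.65 log units; beyond the scatter) shows that an exact number returns when the methyl on the amine nitrogen gives way to a hydrogen, even though the aromatic group carries a methoxy at the same time. The aromatic group also matters more here than the earlier pair suggested: a 1.8-fold higher number from compound 1 to compound 2 (0.26 log units; within the scatter) stayed within the scatter, but a 2.2-fold higher number from compound 2 to compound 4 (0.35 log units; beyond the scatter) and a 4.1-fold higher number from compound 1 to compound 4 (0.61 log units; beyond the scatter) both lie beyond it, so methoxy is not interchangeable with chloro on the aromatic carbon, nor 4-methoxyphenyl with naphthalen-1-yl. The full size of the return cannot be stated, since compound 3 is held only at a limit: the limit of > 50000 nM in this assay, at which 1 of the 4 values shown sits.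

The share of the methyl alone stays open, as the compounds shown do not include a plain benzyl group on an amine that keeps its hydrogen, which would separate the loss of the methyl from the arrival of the methoxy. Also open, from the compounds shown here alone, is how a longer chain, or an amide in place of the amine, would read in this assay.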